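A few compounds are considered here, and "the series" means these few. Any claim that something is new, unique, unknown or untested is made for them only; others in the source may bear on it.

Compound 1 `CCOC(=O)c1cc(-c2cccc(OCc3cccc([N+](=O)[O-])c3)c2)on1` carries a 3-nitrophenyl group on a saturated chain carbon bound to an oxygen on an aromatic ring. In an ADME assay on Vero cells (Chlorocebus sabaeus) for cytotoxicity, with a stated time of 72 h (a lower number here means a stronger inhibitor, a higher number a weaker inhibitor), compound 1 gives > 128000 nM, which is a limit of the assay rather than a number. Compound 2 `CCOC(=O)c1cc(-c2cccc(OCc3ccc(C(F)(F)F)cc3)c2)on1` is the second measured compound. In this assay compound 2 gives > 128000 nM, again a limit of the assay and not a number. Both measured values therefore sit at the limit of > 128000 nM in this assay, at which 2 of the 2 values shown sit, and compound 1 stands at that limit with nothing in the numbers to set it apart from compound 2. Compound 3 `CCOC(=O)c1cc(-c2cccc(OCc3ccc(F)cc3F)c2)on1` has not yet been measured in this assay. It differs from compound 1 in one place: 2,4-difluorophenyl in place of 3-nitrophenyl on a saturated chain carbon bound to an oxygen on an aromatic ring. Among the compounds with values here, no step between measured compounds is known here, and with both measured compounds at the limit, the expectation for this assay is no step beyond the scatter, so the step of a number no higher from compound 1 to compound 3 (the limit leaves the size open) is estimated to stay within it. Compound 3 is expected to give 128000 nM in this assay, with a range from 60000 nM to 128000 nM, and is most likely to be reported only as a limit.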

Compound 3, half-maximal inhibitory concentration: > 128000 nM
Compound 3: no number, only a limit; the forecaster's own chance of this, stated with the estimate: 85%; the middle value lies on the limit itself.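

In this assay, compound 3 gives only a limit, as compound 1 does, so no step between compound 1 and compound 3 can be read: the limit of > 128000 nM in this assay, at which 3 of the 3 values shown sit.

The compounds shown leave open whether any group on the saturated chain carbon bound to an oxygen on an aromatic ring would give a readable number in this assay.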